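A few compounds are considered here, and "the series" means these few. Any claim that something is new, unique, unknown or untested is made for them only; others in the source may bear on it.

Measured so far in a functional assay on DU-145 cells (Homo sapiens) for cytotoxicity, read by MTT assay; on this read-out lower numbers stand for stronger inhibition and higher numbers for weaker inhibition:
- compound 1 `CCCCC(O)CC(=O)O[C@H](CC=C(C)C)C1=CC(=O)c2c(O)ccc(O)c2C1=O`: 45300 nM
- compound 2 `CC[C@](C)(O)CC(=O)O[C@H](CC=C(C)C)C1=CC(=O)c2c(O)ccc(O)c2C1=O`: 20500 nM

Compound 2, at 20500 nM, holds the lower of the two numbers and is thus the stronger inhibitor of this pair. Among the compounds with values here, the only measured step is modest: a 2.2-fold lower number from compound 1 to compound 2 (0.34 log units; beyond the scatter). It swaps one hydroxyalkyl group for another on a saturated chain carbon bound to a carbonyl carbon.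

Compound 3 `CC(C)=CC[C@@H](OCC(C)O)C1=CC(=O)c2c(O)ccc(O)c2C1=O` has not yet been measured in this assay. Its change from compound 2 goes further: 2-hydroxypropyl in place of (2-hydroxy-2-methylbutyl)carbonyl on an oxygen on a saturated carbon. The whole carbonyl-bearing group on that oxygen is replaced, a kind of change that neither measured compound shows. The step of a 2.2-fold lower number from compound 1 to compound 2 (0.34 log units; beyond the scatter) therefore offers only a rough guide to how much this series can move, and the data give no direction for the new change. No step beyond the scatter is confidently expected, though the uncertainty is wide. The expected step is a 1.1-fold lower number from compound 2 to compound 3 (0.06 log units; within the scatter). For compound 3 the estimated value is 18000 nM, with an expected range from 6000 nM to 50000 nM.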

Compound 3, half-maximal inhibitory concentration: 16100 nM
Compound 3: the middle estimate sits 1.1-fold (0.05 log units) above what was measured, within the range that was stated.
By their numbers in this assay, from the lowest: compounds 3 and 2 (each within the scatter of the next); then compound 1.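

On this oxygen on a saturated carbon, the whole carbonyl-bearing group can give way to a group without a carbonyl: in this assay, putting 2-hydroxypropyl in place of (2-hydroxy-2-methylbutyl)carbonyl gives a 1.3-fold lower number from compound 2 to compound 3 (0.10 log units; within the scatter). The entering group has 4 heavy atoms against 8 in the group that leaves, so among these compounds neither the carbonyl nor the larger size is needed to hold the number at the level of compound 2. Measured against the other ester, the same kind of exchange gives a 2.8-fold lower number from compound 1 to compound 3 (0.45 log units; beyond the scatter), so compound 1 stays apart from compound 2 and compound 3, and nothing at hand explains these results or says why the two esters differ from each other.

From the compounds shown here alone, what remains open is whether the hydroxyl of the 2-hydroxypropyl group matters at all, as a plain propyl group on this oxygen would test. Going by these compounds, it is also open whether a longer chain such as 2-hydroxyhexyl, or a group carrying an amine or a carboxylic acid, would move the number in this assay beyond the scatter in either direction.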